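The source may hold more compounds than are shown below. What is called first, only, known or untested is meant among the compounds shown, and "the series" means these compounds.

Measured in a functional assay on A549 cells (Homo sapiens) for inhibition, read by MTT assay, with a stated time of 48 h; on this read-out lower numbers stand for stronger inhibition and higher numbers for weaker inhibition:

Compound 1 `COc1cc(Cn2cc(COc3cccc(/C=C4\C(=O)Nc5ccccc54)c3)nn2)cc(OC)c1`: 43300 nM
Compound 2 `O=C1Nc2ccc(Cl)cc2/C1=C/c1cccc(OCc2cn(Cc3ccccc3)nn2)c1`: > 50000 nM

Only compound 1 has a true number here. On these data alone, the entry for compound 2 is a limit of the assay and not a number, so its exact potency is unknown: the limit of > 50000 nM in this assay, at which 1 of the 2 values shown sits. Among the measured compounds shown here, with just these two compounds, and no measured step between close relatives, the data show nothing about how a change at any one place affects inhibition.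

The next compound is compound 3 `COc1ccc(Cc2ccc3c(c2)/C(=C/c2cccc(OCc4cn(Cc5ccccc5)nn4)c2)C(=O)N3)cc1`. It keeps the rest of compound 2 but carries 4-methoxybenzyl in place of chloro on an aromatic carbon. For the measured compounds named here, this is a large change in counted atoms, but no measured pair shows what such a swap does in this assay. A modest move towards stronger inhibition is therefore expected, and another limit reading would be no surprise. The expected change is an at least 2.0-fold lower number from compound 2 to compound 3 (0.30 log units; that floor lies within the scatter). For compound 3 the estimated value is 25000 nM. The expected range for that estimate runs from 7000 nM to 50000 nM.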

Compound 3, half-maximal inhibitory concentration: 30500 nM
Estimate against measurement, compound 3: 1.2-fold (0.09 log units) below; the range from low to high includes it.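

In this assay compound 3 gives a true number, 30500 nM, so a compound carrying 4-methoxybenzyl on this aromatic carbon, with its added six-membered aromatic ring, still gives a measurable reading. The swap from chloro to 4-methoxybenzyl appears as an at least 1.6-fold lower number from compound 2 to compound 3 (0.21 log units; that floor lies within the scatter), so the data fix only a floor for the step, and that floor does not by itself separate the two compounds. Compound 2 remains a limit of the assay and not a number, so the true size of the change at this position stays unknown: the limit of > 50000 nM in this assay, at which 1 of the 3 values shown sits.

The compounds shown cannot tell whether the reading of compound 3 belongs to the benzyl part or to the methoxy on it, as this single swap brings in both at once. On these data alone, how a plain benzyl, an amine or a carboxylic acid would read on this same aromatic carbon also stays open, and with it whether any group here can give a step that clearly exceeds the usual scatter.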